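The source may hold more compounds than are shown below. What is called first, only, known or untested is meant among the compounds shown, and "the series" means these compounds.

Measured compounds:
- compound 1 `C=CCn1c(=O)/c(=C\c2cccc(Cl)c2)[nH]c(=O)/c1=C\c1ccccc1OC` — 5500 nM
- compound 2 `C=CCn1c(=O)/c(=C\c2ccccc2Cl)[nH]c(=O)/c1=C\c1ccccc1OC` — 5100 nM
- compound 3 `C=CCn1c(=O)/c(=C\c2ccc(F)c(Br)c2)[nH]c(=O)/c1=C\c1ccccc1OC` — "not active" (no number reported)

In a functional assay on HeLa cells (Homo sapiens) for cytotoxicity, read by CCK-8 assay, with a stated time of 72 h (on this read-out lower numbers stand for stronger inhibition and higher numbers for weaker inhibition), compound 3 gave no number, only the outcome "not active" (no number reported), so it stands apart from compound 1 and compound 2, which both gave a value. Compound 4 `C=CCn1c(=O)/c(=C\c2ccc(C)cc2)[nH]c(=O)/c1=C\c1ccccc1OC` differs from compound 3 by 4-methylphenyl in place of 3-bromo-4-fluorophenyl on a double-bonded chain carbon bound to an aromatic carbon. Among the compounds with values here, the only measured step, a 1.1-fold lower number from compound 1 to compound 2 (0.03 log units; within the scatter), moves a chlorine between positions on the same ring and lies within the scatter; it does not speak to replacing a 3-bromo-4-fluorophenyl with a 4-methylphenyl. Compound 1 and compound 2 show that the shared core with a substituted phenyl at this place can reach the range near their values, while compound 3 shows it can also fall out of range. On this basis compound 4 is expected to give a number near those of compound 1 and compound 2, with a wide range, estimated at 6000 nM (between 2500 nM and 20000 nM).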

Compound 4, half-maximal inhibitory concentration: "not active" (no number reported)
Compound 4 has no reported number here; no gap can be computed for the estimate.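

Compound 3 and compound 4 both gave only the outcome "not active" in this assay, so no step can be read between them. Nothing shown here bears on this result. The compounds shown leave open whether 4-methylphenyl and 3-bromo-4-fluorophenyl differ at all in this test.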